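Tolerance in a toxicity assay across three amide variants

The source may report more compounds than this note shows. Statements on the series, on what has been measured and on what is new or still open speak of the compounds shown alone.

Measured so far in a toxicity assay on THP-1 cells (Homo sapiens) for inhibition; a higher number here means that more compound is tolerated, a lower number that less compound is tolerated:
compound 1 `COc1ccc(-c2cnc(NC(=O)c3cnc[nH]3)n2C)cc1` gives > 100000 nM, a limit of the assay rather than a number.
compound 2 `Cn1c(-c2ccccc2Cl)cnc1NC(=O)c1ccc(F)cc1` gives > 50000 nM, again a limit of the assay.
compound 3 `COc1cccc(-c2cnc(NC(=O)c3ccc(F)cc3)n2C)c1` gives > 100000 nM, also a limit of the assay.

Compound 1 therefore stands at the upper limit of this assay, with no numeric value. Two of the three values sit at the limit of > 100000 nM in this assay, at which 2 of the 3 values shown sit, and one at the limit of > 50000 nM in this assay, at which 1 of the 3 values shown sits. Within the data shown here, the only step between compounds differing in one place, a step that the two limits leave unreadable from compound 2 to compound 3, is unreadable since both ends are limits. Compound 4 `COc1ccc(-c2cnc(NC(=O)c3ccc(C)cc3)n2C)cc1` introduces (4-methylphenyl in place of 1H-imidazol-5-yl on a carbonyl carbon). Among the measured compounds shown here, no measured step bears directly on this change; the readable information is that compound 1 and compound 3, which differ at the carbonyl carbon among other places, both report the same limit. On this basis no step beyond the scatter is expected, and the result is expected again to be a limit. For compound 4 the estimate is 100000 nM, ranging from 30000 nM to 300000 nM. That estimate means an expected step of a number no higher from compound 1 to compound 4 (the limit leaves the size open).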

Compound 4, half-maximal cytotoxic concentration: > 100000 nM
Compound 4 was reported as a limit; the forecaster's own chance of this, stated with the estimate: 85%; the middle value sits exactly at the limit.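

Compound 1 and compound 4 both report only a limit of the assay in this assay, and no new step can be read between them. The compounds shown leave open where any of them reaches its half-maximal cytotoxic concentration, and whether the amide variants differ at all.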